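A few compounds are considered here, and "the series" means these few. Any claim that something is new, unique, unknown or untested is made for them only; others in the source may bear on it.

Of the compounds shown here, two have been measured so far in an ADME assay on a cell-free system (plasma, Rattus norvegicus, strain Sprague-Dawley) for metabolic stability, read by LC-MS; on this read-out lower numbers stand for a shorter-lived compound and higher numbers for a longer-lived compound. Compound 1 (`CC(C(=O)OCCOc1ccc2oc(=O)ccc2c1)c1cccc(C(=O)c2ccccc2)c1`) gives 0.0783 h and holds the higher of the two numbers. Compound 2 (`CC(C(=O)OCCOc1ccc2oc(=O)ccc2c1)c1ccc(-c2ccccc2)c(F)c1`) gives 0.0217 h and lies lower, a gap beyond the scatter.

Compound 3 (`CC(C(=O)OCCOc1ccc2ccc(=O)oc2c1)c1cccc(C(=O)c2ccccc2)c1`) has the same atoms as compound 1, joined differently: a group of 11 heavy atoms (9 carbon, 2 oxygen; one six-membered aromatic ring of carbon only, one six-membered aromatic ring with 1 hetero atom) in place of a group of 11 heavy atoms (9 carbon, 2 oxygen; one six-membered aromatic ring of carbon only, one six-membered aromatic ring with 1 hetero atom), on an oxygen on a saturated carbon. Going by the values given here, the exchange sits on an oxygen on a saturated carbon, and no measured pair isolates a change of this kind. The two groups match in every count given, so compound 1 at 0.0783 h is the only anchor, and no step beyond the scatter is expected in either direction in this assay. The estimated step of a 1.1-fold lower number from compound 1 to compound 3 (0.05 log units; within the scatter) stays within the scatter. Compound 3 is estimated at 0.07 h (expected range 0.03 h to 0.17 h).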

Compound 3, half-life: 0.035 h
Beside the measured number, compound 3's estimate is 2.0-fold (0.30 log units) above it, within the range that was stated.
By their numbers in this assay, from the lowest: compounds 2 and 3 (each within the scatter of the next); then compound 1.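

In this assay, going by these compounds alone, the exchange on an oxygen on a saturated carbon gives the first single-place comparison (a 2.2-fold lower number from compound 1 to compound 3 (0.35 log units; beyond the scatter)). The two groups match in every count, each with 11 heavy atoms, one six-membered aromatic ring of carbon only and one six-membered aromatic ring with 1 hetero atom, so the read-out at this position is sensitive to how the same atoms are joined, not only to which atoms are present. Nothing at hand accounts for the size or direction of this step.

One pair cannot show whether the step carries over to another core, and compound 2 has no partner for such a comparison. Also open, going by these compounds, is how the read-out would respond to a group bearing an amine or a carboxylic acid on this oxygen on a saturated carbon.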